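The source may hold more compounds than are shown below. What is called first, only, known or untested is meant among the compounds shown, and "the series" means these compounds.

Working notes on the series

Compound 1 `ClCc1ccc(Cn2cnc3c(Cl)ncnc32)cc1` and compound 2 `ClCc1ccccc1Cn1cnc2ncnc(Cl)c21` share the same atoms joined differently; the difference between the two cores is not broken down here. In a functional assay on A498 cells (Homo sapiens) for cytotoxicity, read by sulforhodamine B assay, with a stated time of 48 h (a lower number here means a stronger inhibitor of growth, a higher number a weaker inhibitor of growth), compound 1 gives 12900 nM and compound 2 gives 18600 nM; the two values lie within the scatter of each other.

Compound 3 `ClCc1ccc(Cn2cnc3c(Cl)nc(Cl)nc32)cc1` carries on the core of compound 1 the change (chloro in place of hydrogen on an aromatic carbon). In this assay compound 3 gives 12000 nM, and the step of a 1.1-fold lower number from compound 1 to compound 3 (0.03 log units; within the scatter) is within the scatter, so the added chloro leaves the growth inhibition essentially unchanged on this core.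

Compound 4 `ClCc1ccccc1Cn1cnc2nc(Cl)nc(Cl)c21` has not been measured. Among the compounds with values here, it carries on the core of compound 2 the change (chloro in place of hydrogen on an aromatic carbon), the same change with the same surroundings as the one from compound 1 to compound 3. The expected step from compound 2 to compound 4 in this assay is a 1.1-fold lower number from compound 2 to compound 4 (0.04 log units; within the scatter), set beside the measured step from compound 1 to compound 3, because a 1.1-fold lower number from compound 1 to compound 3 (0.03 log units; within the scatter) shows no effect beyond the scatter. Compound 4 is therefore expected to give about 17000 nM, most likely between 8500 nM and 34000 nM.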

Compound 4, concentration for 50% growth inhibition: 2510 nM
Compound 4: middle estimate off by 6.8-fold (0.83 log units), on the high side; measured number below the stated range.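

The same change does not carry over unchanged between the two cores: in this assay, chloro in place of hydrogen on an aromatic carbon gives a 7.4-fold lower number from compound 2 to compound 4 (0.87 log units; beyond the scatter), whereas on the core of compound 1 it leaves the number within the scatter. The size of the step therefore depends on the core that carries the change, so the step measured on one core could not be transferred to the other: the same change on two cores in this assay, a 1.1-fold lower number (0.03 log units; within the scatter) from compound 1 to compound 3 and a 7.4-fold lower number (0.87 log units; beyond the scatter) from compound 2 to compound 4, 6.9-fold (0.84 log units) apart, beyond the scatter of two such steps

This rests on a single pair of steps and does not show which feature of the two cores separates them, nor does it give a rule for any further core.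

Going by these compounds, it remains open whether another group on the same carbon between two ring nitrogen atoms, such as an amine or a methoxy group, would split between the two cores in the same way. On these data alone, it is also open whether the larger step on the core of compound 2 would persist with a hydroxymethyl group in place of the chloromethyl group.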